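A few compounds are considered here, and "the series" means these few. Any claim that something is new, unique, unknown or untested is made for them only; others in the source may bear on it.

Of the compounds shown here, three sharing one core have been tested in a functional assay on SK-OV-3 cells (Homo sapiens) for antiproliferative activity, read by MTT assay, with a stated time of 24 h; on this read-out lower numbers stand for stronger inhibition and higher numbers for weaker inhibition: compound 1 `COc1ccc(C(=O)/C=C/c2ccc(F)cc2)c2c1C=CC(C)(C)O2`, compound 2 `COc1ccccc1/C=C/C(=O)c1ccc(OC)c2c1OC(C)(C)C=C2` and compound 3 `COc1ccc(C(=O)/C=C/c2ccc(O)cc2)c2c1C=CC(C)(C)O2`. Compound 1 gives > 10000 nM, which is a limit of the assay and not a number. Compound 2 likewise gives the limit > 10000 nM. Compound 3 also gives only a limit, > 10000 nM. That is the limit of > 10000 nM in this assay, at which 3 of the 3 values shown sit. Compound 4 `COc1ccc(C(=O)/C=C/c2ccc(O)c(Br)c2)c2c1C=CC(C)(C)O2` differs from compound 3 by one change, bromo in place of hydrogen on an aromatic carbon, ortho to a hydroxy group. The nearest measured changes, a step that the two limits leave unreadable from compound 1 to compound 3 and a step that the two limits leave unreadable from compound 2 to compound 3, offer no size to carry over. The estimated step is therefore a step that the limit leaves unreadable from compound 3 to compound 4, with no clear direction expected. For compound 4 the expected value is 12000 nM, within an estimated range of 3000 nM to 30000 nM.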

Compound 4, half-maximal inhibitory concentration: > 10000 nM
Compound 4 gave a limit, no number; the forecaster's own chance of this, stated with the estimate: 65%; the middle value is on the limit's open side.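

Among the compounds shown here, no step to compound 4 can be read from compound 1, compound 2 or compound 3, since all four results are limits and not numbers: the limit of > 10000 nM in this assay, at which 4 of the 4 values shown sit. In this assay the compounds shown leave open whether any change on the shared core gives a readable number.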